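From dichlorophenyl to dimethylaminophenyl: the step to compound 4

This account rests on a few compounds, and the source may have more. Where it says the series, first, only, none or still open, it means among the compounds named here.

- compound 1 `O=C(/C(=C\c1ccc(Cl)cc1Cl)S(=O)(=O)c1ccc(Br)cc1)c1ccc(Cl)cc1` in a functional assay on DU-145 cells (Homo sapiens) for inhibition, read by trypan blue exclusion, with a stated time of 96 h (on this read-out lower numbers stand for stronger inhibition of growth and higher numbers for weaker inhibition of growth), gives 50000 nM
- compound 2 `O=C(/C(=C\c1ccc(O)c([N+](=O)[O-])c1)SCc1ccc(Br)cc1)c1ccc(Cl)cc1Cl` gives 10000 nM
- compound 3 `Cc1ccc(CS/C(=C/c2ccc(F)c([N+](=O)[O-])c2)C(=O)c2ccc(Cl)c([N+](=O)[O-])c2)cc1` gives 1000 nM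

Compound 1 at 50000 nM stands highest of the three, with compound 2 and compound 3 both lower beyond the scatter. Compound 4 `CN(C)c1ccc(/C=C(\C(=O)c2ccc(Cl)cc2)S(=O)(=O)c2ccc(Br)cc2)cc1` carries 4-(dimethylamino)phenyl in place of 2,4-dichlorophenyl on a double-bonded chain carbon bound to a double-bonded chain carbon and otherwise keeps the core of compound 1. Within the data shown here, no measured pair differs in one place, so the step in this assay has no direct precedent. A modest move toward a lower number is expected, since compound 1 at 50000 nM sits at the top of the values. The expected step is a 2.5-fold lower number from compound 1 to compound 4 (0.40 log units; beyond the scatter), with wide uncertainty. Compound 4 is estimated at 20000 nM, with a range from 3000 nM to 100000 nM in that estimate.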

Compound 4, concentration for 50% growth inhibition: > 100000 nM
Compound 4: a limit, no number (the forecaster's own chance of this, stated with the estimate: 15%); at least 5.0-fold (0.69 log units) between middle value and limit.
By their numbers in this assay, from the lowest: compound 3; then compound 2; then compound 1. At a limit, above all of these: compound 4.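

Compound 4 gives > 100000 nM in this assay, which is a limit of the assay and not a number. Among these compounds, the change from 2,4-dichlorophenyl to 4-(dimethylamino)phenyl on a double-bonded chain carbon bound to a double-bonded chain carbon is the first one-place step, and it gives an at least 2.0-fold higher number from compound 1 to compound 4 (0.30 log units; that floor lies within the scatter). Only the floor of this step can be read, not its size: the limit of > 100000 nM in this assay, at which 1 of the 4 values shown sits.

Open, as far as these compounds go, is whether a phenyl ring carrying a primary amine or a carboxylic acid at this place gives a number within range in this assay. Also open, from the compounds shown here alone, is whether 4-(dimethylamino)phenyl has the same effect on the cores of compound 2 and compound 3.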